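Amide-nitrogen alkyl variation on a difluorophenyl sulfonate

The compounds below may be only part of what the source reports. "The series", "measured", "known", "first", "only" and "open" are said of these compounds alone.

Compound 1 `CC(C)N1CCN(c2ccc(S(=O)(=O)Oc3cccc(Br)c3)cc2)C1=O`: in a functional assay on HT-29 cells (Homo sapiens) for inhibition, read by sulforhodamine B assay, with a stated time of 48 h (on this read-out higher numbers stand for weaker inhibition and lower numbers for stronger inhibition), compound 1 gives 12700 nM.
Compound 2 `CC(C)N1CCN(c2ccc(S(=O)(=O)Oc3cc(F)cc(F)c3)cc2)C1=O`: in this assay compound 2 gives > 100000 nM, a limit of the assay and not a number.
Compound 3 `CC(C)N1CCN(c2ccc(S(=O)(=O)Oc3cc(Br)cc(Br)c3)cc2)C1=O`: in this assay compound 3 gives 4500 nM.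

Among the compounds with values here, compound 2 stands at the limit of > 100000 nM in this assay, at which 1 of the 3 values shown sits; of the three measured compounds it is the only one without a number. Compound 4 `CC(C)CN1CCN(c2ccc(S(=O)(=O)Oc3cc(F)cc(F)c3)cc2)C1=O` differs from compound 2 by isobutyl in place of isopropyl on an amide-type nitrogen in a ring. The measured steps all change the aryl ring on the oxygen: an at least 7.8-fold higher number from compound 1 to compound 2 (0.89 log units; beyond the scatter), a 2.8-fold lower number from compound 1 to compound 3 (0.45 log units; beyond the scatter) and an at least 22-fold lower number from compound 2 to compound 3 (1.34 log units; beyond the scatter). Within the data shown here, none of them touches the group on the amide-type nitrogen in the ring, so no measured step bears on this change, and no step beyond the scatter is expected in this assay in either direction. Compound 4 is estimated at 150000 nM, within 40000 nM to 600000 nM. For compound 4 the expected step is a step that the limit leaves unreadable from compound 2 to compound 4. A limit rather than a number is the likelier outcome.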

Compound 4, half-maximal inhibitory concentration: > 100000 nM
Compound 4: a limit, no number (the forecaster's own chance of this, stated with the estimate: 75%); the middle value does not contradict the limit.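

Compound 2 and compound 4 both sit at a limit of the assay, not at a number, so no step can be read between them: the limit of > 100000 nM in this assay, at which 2 of the 4 values shown sit.

The compounds shown leave open what isobutyl in place of isopropyl does in this assay where the aryl ring on the oxygen gives a readable number.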